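Chain length at the isothiocyanate end and cell inhibition

The source may hold more compounds than are shown below. What is called first, only, known or untested is meant among the compounds shown, and "the series" means these compounds.

Compound 1: `CN(C)C(=O)c1cc2cnc(Nc3ccc(C(=O)NCCCCCCCN=C=S)cc3)nc2n1C1CCCC1` gives 101%
Compound 2: `CN(C)C(=O)c1cc2cnc(Nc3ccc(C(=O)NCCCN=C=S)cc3F)nc2n1C1CCCC1` gives 60.2%
Compound 3: `CN(C)C(=O)c1cc2cnc(Nc3ccc(C(=O)NCCCCCN=C=S)cc3F)nc2n1C1CCCC1` gives 15.6%

All three compounds share one core and were tested in a functional assay on A549 cells (Homo sapiens) for inhibition, read by CCK-8 assay, with a stated time of 72 h, tested at 10 uM; a lower number here means a weaker effect, a higher number a stronger effect of the compound at the concentration tested. Compound 3 stands lowest of the three numbers, beyond the scatter from compound 2 and further still from compound 1. Going by the values given here, the only step that bears on the next compound is a number 44.6 percentage points lower from compound 2 to compound 3 (beyond the scatter), where a longer chain brought a sharp fall. Compound 4, `CN(C)C(=O)c1cc2cnc(Nc3ccc(C(=O)NCCCCCCCN=C=S)cc3F)nc2n1C1CCCC1`, is not yet measured; it differs from compound 3 by a group of 5 heavy atoms (3 carbon, 1 nitrogen, 1 sulfur; no ring) in place of a group of 3 heavy atoms (1 carbon, 1 nitrogen, 1 sulfur; no ring), on a saturated chain carbon, five bonds along the chain from an amide-type nitrogen. That step points to no gain or a further fall, yet compound 3 is already low, and compound 1, carrying the same long chain, shows the highest number. The estimate for compound 4 is therefore 35%, expected between 5% and 90%, an expected step of a number 19.4 percentage points higher from compound 3 to compound 4 (beyond the scatter).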

Compound 4, a percentage reported as inhibition, at one concentration (the size of the read-out at that concentration, not a potency): 12.7%
The estimate for compound 4 lay 22.3 percentage points above the measured number; measured number inside the range.
By their numbers in this assay, from the lowest: compounds 4 and 3 (each within the scatter of the next); then compound 2; then compound 1.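

In this assay, extending the chain at this place gives (a number 2.9 percentage points lower from compound 3 to compound 4 (within the scatter)), so the two longer chains stand level, while the shortest chain remains apart (a number 47.5 percentage points lower from compound 2 to compound 4 (beyond the scatter)). The result also supplies a pair that differs only in fluoro in place of hydrogen on an aromatic carbon, and with the longest chain this change gives (a number 88.3 percentage points lower from compound 1 to compound 4 (beyond the scatter)). No measurement shown here offers an explanation for these steps. The compounds shown leave open whether fluoro in place of hydrogen has the same outcome on the shorter chains. They also leave open how an amine in place of the isothiocyanate end would read.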